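The compounds below may be only part of what the source reports. "The series", "measured", "known", "first", "only" and "open" are said of these compounds alone.

Working notes on the series.

Two members of the series have numbers. Compound 1 `COc1cc2c(Oc3ccc(NC(=O)c4cc(-c5ccc(F)cc5)ccn4)cc3F)ccnc2cc1OCCCN1CCN(C)CC1` gives 430 nM in a functional assay on NCI-H460 cells (Homo sapiens) for cytotoxicity, read by MTT assay, with a stated time of 72 h; on this read-out higher numbers stand for weaker inhibition and lower numbers for stronger inhibition. Compound 2 `COc1cc2c(Oc3ccc(NC(=O)c4cc(-c5ccccc5C)ccn4)cc3F)ccnc2cc1OCCCN1CCCC1` gives 420 nM in this assay, the lowest of the two numbers, with compound 1 nearest at a gap that lies within the scatter; the two compounds therefore read the same on this count.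

The next step goes from compound 2 to compound 3 `COc1cc2c(Oc3ccc(NC(=O)c4cc(-c5ccc(F)cc5)ccn4)cc3F)ccnc2cc1OCCCN1CCCC1`, not yet measured in this assay. The change is 4-fluorophenyl in place of 2-methylphenyl on an aromatic carbon. Within the data shown here, no pair of measured compounds shows this change in isolation, so no measured step can be quoted for it. Among the measured compounds shown here, compound 1 also carries a 4-fluorophenyl at the same place and gives 430 nM, which is the only guide. On that basis the expected step of no change at the digits printed from compound 2 to compound 3 (within the scatter) is none beyond the scatter. Compound 3 is estimated at 420 nM, with a range from 200 nM to 900 nM.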

Compound 3, half-maximal inhibitory concentration: 370 nM
For compound 3 the middle estimate is 1.1-fold (0.06 log units) above the measured one, and the stated range covers the measured number.
By their numbers in this assay, from the lowest: compounds 3, 2 and 1 (each within the scatter of the next).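

In this assay, the change from 2-methylphenyl to 4-fluorophenyl on the aromatic carbon opposite the ring nitrogen now has a measured step, a 1.1-fold lower number from compound 2 to compound 3 (0.06 log units; within the scatter), so the two groups cannot be told apart at this position. Among these compounds, the far end of the chain also becomes readable for the first time: pyrrolidin-1-yl in place of 4-methylpiperazin-1-yl gives a 1.2-fold lower number from compound 1 to compound 3 (0.07 log units; within the scatter), so neither change moves the number beyond the scatter. No measurement of any property of these groups bears on this result.

The step from 2-methylphenyl to 4-fluorophenyl changes both the substituent and its place on the phenyl ring, so the two contributions cannot be separated. On these data alone, whether an amine or a carboxylic acid on that ring, or morpholin-4-yl or a longer chain at the chain end, would give a step beyond the scatter stays open.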